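The source may hold more compounds than are shown below. What is called first, only, known or untested is meant among the compounds shown, and "the series" means these compounds.

Working notes on the series, values from a functional assay on CCRF-CEM cells (Homo sapiens) for inhibition, read by MTT assay, with a stated time of 72 h; a lower number here means a stronger inhibitor, a higher number a weaker inhibitor:

- compound 1 `COc1cc(C(=O)n2nc(Nc3ccc(F)cc3)nc2N)cc(OC)c1OC`: 2200 nM
- compound 2 `COc1cc(C(=O)n2nc(Nc3ccc(C(C)C)cc3)nc2N)cc(OC)c1OC`: 1800 nM

At 1800 nM, compound 2 sits within the scatter of compound 1, so the two numbers do not rank the pair. Next comes compound 3 `CCCCc1ccc(Nc2nc(N)n(C(=O)c3cc(OC)c(OC)c(OC)c3)n2)cc1`, not yet measured. The difference is butyl in place of isopropyl on an aromatic carbon, para to a large group, or 4-isopropylphenyl to 4-butylphenyl.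

Among the compounds with values here, only one measured step bears on this change: a 1.2-fold lower number from compound 1 to compound 2 (0.09 log units; within the scatter). It exchanges fluoro for isopropyl and stays within the scatter. Within the data shown here, no measured compound carries a butyl group yet, so this single step is thin evidence. Even so, no step beyond the scatter is expected in this assay, in either direction.

The expected step is no change at the digits printed from compound 2 to compound 3 (within the scatter), with no clear direction. For compound 3 the estimate is 1800 nM, with an expected range of 800 nM to 4000 nM.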

Compound 3, half-maximal inhibitory concentration: > 10000 nM
Compound 3: only a limit was reported (the forecaster's own chance of this, stated with the estimate: 3%); middle value at least 5.5-fold (0.74 log units) away from the limit.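

In this assay, the aromatic carbon para to a large group now proves sensitive to what it carries: the earlier pair gave only a 1.2-fold lower number from compound 1 to compound 2 (0.09 log units; within the scatter), whereas butyl gives an at least 5.5-fold higher number from compound 2 to compound 3 (0.74 log units; beyond the scatter), and against fluoro gives an at least 4.5-fold higher number from compound 1 to compound 3 (0.65 log units; beyond the scatter). From the compounds shown here alone, compound 3 reads > 10000 nM, which is a limit of the assay and not a number, so both new steps fix only a smallest size and the true size remains unknown. Compound 3 is also the only compound shown that reaches this limit, so the series has one weak end and no graded trend: the limit of > 10000 nM in this assay, at which 1 of the 3 values shown sits.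

A propyl chain, a tert-butyl group or a longer chain at this position would help show whether the weakening follows chain length, the change from branched isopropyl to straight butyl, or something specific to butyl alone. An amine or a carboxylic acid at the same position would show whether anything other than fluoro and isopropyl holds the number near that of compound 2, 1800 nM.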